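Shifting the chloro substituent on the amide-linked phenyl

This account rests on a few compounds, and the source may have more. Where it says the series, first, only, none or still open, it means among the compounds named here.

Measured in a functional assay on CHO cells for antagonist activity at Orexin/Hypocretin receptor type 1 (Homo sapiens), read by FLIPR and calcium flux; a higher number here means a weaker inhibitor, a lower number a stronger inhibitor:
compound 1 `Cc1ccc(NC(=O)CSc2nnc(-c3ccoc3C)n2Cc2ccco2)cc1`: > 15800 nM
compound 2 `Cc1cccc(NC(=O)CSc2nnc(-c3ccoc3C)n2Cc2ccco2)c1`: 2510 nM
compound 3 `Cc1occc1-c1nnc(SCC(=O)Nc2ccc(Cl)cc2)n1Cc1ccco1`: 2000 nM

The value of compound 1 is a limit of this assay (the limit of > 15800 nM in this assay, at which 1 of the 3 values shown sits). Compound 3 gives the lowest of the two actual numbers, but it sits within the scatter of compound 2 (a 1.3-fold lower number from compound 2 to compound 3 (0.10 log units; within the scatter)). Compound 4 `Cc1occc1-c1nnc(SCC(=O)Nc2cccc(Cl)c2)n1Cc1ccco1` is not yet measured; it carries 3-chlorophenyl in place of 4-chlorophenyl on an amide-type nitrogen. The closest measured step moves a methyl in the same way, an at least 6.2-fold lower number from compound 1 to compound 2 (0.79 log units; beyond the scatter), and the methyl-to-chloro step an at least 7.9-fold lower number from compound 1 to compound 3 (0.89 log units; beyond the scatter) ran in the same direction. A lower number is therefore expected for compound 4, of modest size: a 2.9-fold lower number from compound 3 to compound 4 (0.46 log units; beyond the scatter). Compound 4 is estimated at 700 nM, within 250 nM to 2500 nM.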

Compound 4, inhibition constant: 2000 nM
The estimate for compound 4 lay 2.9-fold (0.46 log units) below the measured number; measured number inside the range.
By their numbers in this assay, from the lowest: compounds 3, 4 and 2 (each within the scatter of the next). At a limit, above all of these: compound 1.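

In this assay, 3-chlorophenyl in place of 4-chlorophenyl on an amide-type nitrogen gives no change at the digits printed from compound 3 to compound 4 (within the scatter), so moving the chloro does not register here as moving the methyl did. Chloro in place of methyl gives a 1.3-fold lower number from compound 2 to compound 4 (0.10 log units; within the scatter), and 3-chlorophenyl in place of 4-methylphenyl gives an at least 7.9-fold lower number from compound 1 to compound 4 (0.89 log units; beyond the scatter), leaving only compound 1, whose value is a limit, apart from the others. The size of the methyl-to-chloro step therefore depends on where the group sits: the same change on two cores in this assay, an at least 7.9-fold lower number (0.89 log units; beyond the scatter) from compound 1 to compound 3 and a 1.3-fold lower number (0.10 log units; within the scatter) from compound 2 to compound 4, at least 6.2-fold (0.79 log units) apart, beyond the scatter of two such steps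

Open, going by these compounds, is whether a carboxylic acid or an amine on the phenyl ring would move the number beyond the scatter of compound 2, compound 3 and compound 4.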